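A few compounds are considered here, and "the series" means these few. Any claim that something is new, unique, unknown or untested is made for them only; others in the source may bear on it.

Measured so far in a functional assay on NCI-H1299 cells (Homo sapiens) for inhibition, read by sulforhodamine B assay, with a stated time of 48 h; on this read-out lower numbers stand for stronger inhibition and higher numbers for weaker inhibition:
- compound 1 `N#Cc1c(NC(=O)CNc2n[nH]c3ncccc23)sc2c1CCCC2`: 12.5 nM
- compound 2 `N#Cc1c(NC(=O)CN/N=C/c2cccc([N+](=O)[O-])c2)sc2c1CCCC2`: 18500 nM

Of these two numbers, compound 2 has the higher one, at 18500 nM, which makes it the weaker inhibitor. The gap to compound 1, at 12.5 nM, lies far beyond the usual scatter of repeated measurements.

The next compound to be measured is compound 3 `COc1ccc(/C=N/NCC(=O)Nc2sc3c(c2C#N)CCCC3)cc1`. It keeps everything in compound 2 except one group: 4-methoxyphenyl in place of 3-nitrophenyl on a carbon with a double bond to nitrogen. In words, it has 4-methoxyphenyl in place of 3-nitrophenyl on a carbon with a double bond to nitrogen.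

Among the compounds with values here, no measured pair shows what this swap does, and compound 1 carries a different group on the shared core, so it offers no direct guide. The best starting point is therefore compound 2 itself, at 18500 nM. The new compound keeps the same chain and still ends in a substituted aromatic ring, so no large move is expected in this assay.

The expected change is a 1.2-fold lower number from compound 2 to compound 3 (0.09 log units; within the scatter), which would stay within the scatter. Compound 3 is estimated at 15000 nM, with an expected range from 4000 nM to 60000 nM.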

Compound 3, half-maximal inhibitory concentration: 18500 nM
Compound 3: the middle estimate sits 1.2-fold (0.09 log units) below what was measured, and the stated range covers the measured number.
By their numbers in this assay, from the lowest: compound 1; then compounds 2 and 3 (each within the scatter of the next).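

In this assay, within the data shown here, putting 4-methoxyphenyl in place of 3-nitrophenyl on a carbon with a double bond to nitrogen gives no change at the digits printed from compound 2 to compound 3 (within the scatter), the first direct reading of a swap at this position. The two groups cannot be told apart here, even though the swap changes the substituent on the aromatic ring, its place on that ring, and the count of hydrogen-bond acceptors from 2 to 1. No measurement offered here explains why the number holds. A single step also cannot show which of these differences matter, or whether they offset each other.

Going by these compounds, what remains open is how each difference acts alone: plain phenyl, 4-nitrophenyl or 3-methoxyphenyl on this carbon would separate the effect of the substituent from that of its place on the ring. Also open, on these data alone, is whether a group of another kind here, such as a carboxylic acid, an amine or a longer chain, would move the number away from that of compound 3 18500 nM.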